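A few compounds are considered here, and "the series" means these few. Any claim that something is new, unique, unknown or untested is made for them only; others in the source may bear on it.

Measured compounds:
Compound 1, `Cc1cc(-c2ccc(Cl)cc2Cl)c(S(C)(=O)=O)cc1C(=O)N=C(N)N`: in a functional assay for inhibition of sodium/hydrogen exchanger (Oryctolagus cuniculus) (a lower number here means a stronger inhibitor, a higher number a weaker inhibitor), compound 1 gives 42 nM.
Compound 2, `Cc1cc(Oc2ccccc2Cl)c(S(C)(=O)=O)cc1C(=O)N=C(N)N`: in this assay compound 2 gives 14 nM.

Compound 2 stands at the lowest of the two numbers in this assay; its nearest neighbour is compound 1, and the step of a 3.0-fold lower number from compound 1 to compound 2 (0.48 log units; beyond the scatter) lies beyond the scatter. The next compound, compound 3, `Cc1cc(C#N)c(S(C)(=O)=O)cc1C(=O)N=C(N)N`, has not yet been measured in this assay. It differs from compound 2 as follows: cyano in place of 2-chlorophenoxy on an aromatic carbon.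

For the measured compounds named here, only one measured step exists, a 3.0-fold lower number from compound 1 to compound 2 (0.48 log units; beyond the scatter), and it bears on the change to compound 3 only loosely: there the aromatic ring on that carbon stayed, joined through oxygen instead of directly, whereas in compound 3 the whole 2-chlorophenoxy group leaves and a small cyano group enters. Going by the values given here, no measured pair shows what a group of two heavy atoms does at that place. On this thin basis the expected step of a 4.3-fold higher number from compound 2 to compound 3 (0.63 log units; beyond the scatter) points to a modestly higher number, with wide uncertainty. For compound 3 in this assay the estimate is 60 nM, within a range from 12 nM to 300 nM.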

Compound 3, half-maximal inhibitory concentration: 70 nM
The estimate for compound 3 lay 1.2-fold (0.07 log units) below the measured number, within the range that was stated.
By their numbers in this assay, from the lowest: compound 2; then compounds 1 and 3 (each within the scatter of the next).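

The carbon ortho to a methylsulfonyl group now carries cyano, a group with no ring, and the change from 2-chlorophenoxy to cyano gives a 5.0-fold higher number from compound 2 to compound 3 (0.70 log units; beyond the scatter) in this assay. Having a ring at this place is not enough on its own to separate compounds, however: a 1.7-fold higher number from compound 1 to compound 3 (0.22 log units; within the scatter) shows that the 2,4-dichlorophenyl group and cyano cannot be told apart here, despite the difference in their size and in the presence of a ring, so among these three only the 2-chlorophenoxy group of compound 2 stands out. No evidence is at hand that would explain either step.

The compounds shown leave open what other small groups at this carbon, such as an amine, a methoxy group or a carboxylic acid, would do relative to cyano. They also leave open whether the oxygen link or the chlorine pattern matters more in the 2-chlorophenoxy group, a question that an unsubstituted phenoxy group or a 2-chlorophenyl group joined directly would address.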